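This account rests on a few compounds, and the source may have more. Where it says the series, first, only, none or still open, it means among the compounds named here.

Measured in a functional assay on A549 cells (Homo sapiens) for cytotoxicity, read by MTT assay, with a stated time of 72 h; on this read-out higher numbers stand for weaker inhibition and lower numbers for stronger inhibition:
- compound 1 `CC(C)(C)C1=CC(=O)C=C(NCCC(=O)O)C1=O`: 171000 nM
- compound 2 `CC(C)(C)C1=CC(=O)C=C(NCC(=O)O)C1=O`: > 200000 nM, a limit of the assay and not a number
- compound 3 `CC1=CCC[C@H]2[C@](C)(CC3=CC(=O)C(N4CCC[C@H]4C(=O)O)=CC3=O)[C@@H](C)CC[C@]12C`: 49200 nM

Compound 3 has the lowest number here: compound 3 gives 49200 nM, clearly under compound 1 at 171000 nM.

Compound 4 `CC1=CCC[C@H]2[C@](C)(CC3=CC(=O)C=CC3=O)[C@@H](C)CC[C@]12C` arises from compound 3 by a single change, hydrogen in place of 2-carboxypyrrolidin-1-yl on a double-bonded ring carbon.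

Among the compounds with values here, the only measured step, an at least 1.1-fold higher number from compound 1 to compound 2 (0.06 log units; that floor lies within the scatter), alters a carboxy-bearing chain without removing it. That step ends at the limit of > 200000 nM in this assay, at which 1 of the 3 values shown sits, so it sets no size for the change at hand. All three measured compounds carry a carboxy group, and compound 4 would be the first without one, so the expectation is a judgement with wide uncertainty. A moderately lower number is expected, with the expected step being a 3.3-fold lower number from compound 3 to compound 4 (0.52 log units; beyond the scatter). For compound 4 the estimate is 15000 nM, with an expected range from 4000 nM to 50000 nM.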

Compound 4, half-maximal inhibitory concentration: 30000 nM
Compound 4: the middle estimate sits 2.0-fold (0.30 log units) below what was measured; measured number inside the range.
By their numbers in this assay, from the lowest: compounds 4 and 3 (each within the scatter of the next); then compound 1. At a limit, above all of these: compound 2.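

In this assay the step is a 1.6-fold lower number from compound 3 to compound 4 (0.21 log units; within the scatter) and so the two values cannot be told apart. The earlier compounds shown here all carried a carboxy group, whereas compound 4 has only hydrogen on this double-bonded ring carbon, which shows that the 2-carboxypyrrolidin-1-yl group can leave the shared core without a change beyond the scatter. Nothing among the data shown explains this outcome.

Going by these compounds, whether the carboxy group and the five-membered ring of the departed group each matter on their own stays open, since they left together. A plain pyrrolidin-1-yl group, which keeps the ring without the carboxylic acid, or a small amine such as dimethylamino on this carbon could still move the number in either direction.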